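A halogen exchange from compound 2 to compound 3

The source may hold more compounds than are shown below. What is called first, only, known or untested is meant among the compounds shown, and "the series" means these compounds.

compound 1 `C=CC(=O)N1C(=O)CC(c2ccc(OC)cc2)Sc2ccccc21`: 43300 nM
compound 2 `C=CC(=O)N1C(=O)CC(c2ccc(Br)cc2)Sc2ccccc21`: 51300 nM

Both values come from a functional assay on Raji cells (Homo sapiens) for cytotoxicity, read by CCK-8 assay, with a stated time of 24 h; a higher number here means a weaker inhibitor, a lower number a stronger inhibitor. Within the data shown here, compound 2, at 51300 nM, lies within the scatter of compound 1, so the two measurements set no order between these compounds.

The next compound is compound 3 `C=CC(=O)N1C(=O)CC(c2ccc(Cl)cc2)Sc2ccccc21`, which shares the core of compound 2 and has chloro in place of bromo on an aromatic carbon, para to a large group: chloro in place of bromo on an aromatic carbon.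

Among the measured compounds shown here, only one measured step bears on this exchange: a 1.2-fold higher number from compound 1 to compound 2 (0.07 log units; within the scatter). That step, bromo in place of methoxy on an aromatic carbon, stayed inside the scatter. For the measured compounds named here, no measured compound yet carries chloro, so the evidence is thin and gives no direction. No step beyond the scatter is therefore expected in this assay. The expected change amounts to a 1.1-fold lower number from compound 2 to compound 3 (0.04 log units; within the scatter), which is an estimate and implies no real difference. The estimated value for compound 3 is 47000 nM, with an expected range from 26000 nM to 85000 nM.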

Compound 3, half-maximal inhibitory concentration: 18400 nM
Estimate against measurement, compound 3: 2.6-fold (0.41 log units) above, and the stated range ends above it.
By their numbers in this assay, from the lowest: compound 3; then compounds 1 and 2 (each within the scatter of the next).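

In this assay, the aromatic position para to a large group now proves sensitive to its substituent, a point the earlier pair could not establish: a 2.8-fold lower number from compound 2 to compound 3 (0.45 log units; beyond the scatter), and a 2.4-fold lower number from compound 1 to compound 3 (0.37 log units; beyond the scatter). Both steps are modest, but both lie beyond the scatter, so compound 3 is the most potent of the three, whereas bromo and methoxy had set no order between themselves. Nothing available here accounts for why chloro separates from these two groups when it replaces bromo with a single halogen atom at the same place, and the result stands as an observation without an explanation.

On these data alone, what remains open is whether this gain is particular to chloro or would also appear with fluoro, iodo, methyl or a trifluoromethyl group at the same carbon, or with a plain hydrogen there. The three compounds also all keep the shared core and carry their group at this one place, so they do not say whether chloro would give a similar step elsewhere on the ring.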